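Swapping the Cyclohexyl Amide for a Piperazine Urea

This account rests on a few compounds, and the source may have more. Where it says the series, first, only, none or still open, it means among the compounds named here.

Compound 3 `CC(C)(C)c1cc(NC(=O)[C@@H]2CCCCN2C(=O)C2CCCCC2)no1` stands at the top of the three measured compounds: in an ADME assay (liver) for metabolic stability, with Liver microsome (Homo sapiens) as the target, read by LC-MS, using microsomes and NADPH, tested at 1 uM (on this read-out lower numbers stand for a shorter-lived compound and higher numbers for a longer-lived compound), compound 3 gives 0.483 h. Compound 1 `CC(C)CN1CCCC[C@H]1C(=O)Nc1cc(C(C)(C)C)on1` gives 0.1 h in this assay, and compound 2 `CC(C)(C)c1cc(NC(=O)[C@@H]2CCCCN2CC2CCOCC2)no1` gives 0.183 h. The step of a 4.8-fold higher number from compound 1 to compound 3 (0.68 log units; beyond the scatter) and the step of a 2.6-fold higher number from compound 2 to compound 3 (0.42 log units; beyond the scatter) both set compound 3 apart, whereas the step of a 1.8-fold higher number from compound 1 to compound 2 (0.26 log units; within the scatter) does not.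

Compound 4 `CCC(=O)N1CCN(C(=O)N2CCCC[C@H]2C(=O)Nc2cc(C(C)(C)C)on2)CC1` differs from compound 3 in one place: 4-propanoylpiperazin-1-yl in place of cyclohexyl on a carbonyl carbon. The amide-type nitrogen in the ring is kept, so what changes is only the group on its carbonyl carbon. Within the data shown here, no measured step alters that group; the steps that bear on the change are those in which the cyclohexylcarbonyl entered, and they were modest in size. Since compound 4 keeps the acylated ring nitrogen that carried compound 3 upward, the expectation is a step in this assay that is small, in either direction, or none beyond the scatter. Compound 4 is therefore expected to give about 0.7 h in this assay, within a range from 0.3 h to 1.7 h. That estimate means an expected step of a 1.4-fold higher number from compound 3 to compound 4 (0.16 log units; within the scatter).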

Compound 4, half-life: > 2 h
Compound 4 ended at the assay's limit; the forecaster's own chance of this, stated with the estimate: 15%; at least 2.8-fold (0.45 log units) between middle value and limit.
By their numbers in this assay, from the lowest: compounds 1 and 2 (each within the scatter of the next); then compound 3. At a limit, above all of these: compound 4.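

Compound 4 gives > 2 h in this assay, which is a limit of the assay and not a number: the limit of > 2 h in this assay, at which 1 of the 4 values shown sits.

The earlier steps shown here showed only what followed when cyclohexylcarbonyl replaced an alkyl group on the amine nitrogen in a ring, and they left the group on the carbonyl carbon untouched. This change shows that the group on that carbonyl carbon matters in its own right: with the amide-type nitrogen in the ring kept, 4-propanoylpiperazin-1-yl in place of cyclohexyl gives an at least 4.1-fold higher number from compound 3 to compound 4 (0.61 log units; beyond the scatter). The half-life thus moves beyond the scatter with no change at the ring nitrogen, and the printed size of this step is only its lower bound.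

The compounds shown do not separate the piperazine ring from the propanoyl group, so it stays open which part of the entering group goes with the step, and whether a morpholine or an unacylated piperazine on the same carbonyl carbon would read alike. As far as these compounds go, the upper end of the step also stays open, and the change is seen on this one pair alone, in this single assay.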